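A few compounds are considered here, and "the series" means these few. Any claim that something is new, unique, unknown or untested is made for them only; others in the source may bear on it.

Working notes on the series. Three compounds share one core and differ only in the group on the carbonyl carbon. Compound 1 `CC(C)[C@@H](NC(=O)c1cccc(F)c1)C(=O)N1CCC(c2ccc(Cl)cc2)CC1` gives 24 nM in an assay on THP-1 cells for displacement of a labelled ligand from C-C chemokine receptor type 1 (Homo sapiens); a higher number here means a weaker inhibitor, a lower number a stronger inhibitor. Compound 2 `Cc1ccccc1CCC(=O)N[C@@H](C(=O)N1CCC(c2ccc(Cl)cc2)CC1)C(C)C` gives 19 nM in this assay. Compound 3 `CC(C)[C@@H](NC(=O)c1nc2ccccc2s1)C(=O)N1CCC(c2ccc(Cl)cc2)CC1` gives 18 nM in this assay. Compound 3 has the lowest of the three numbers, but both neighbouring steps, a 1.1-fold lower number from compound 2 to compound 3 (0.02 log units; within the scatter) and a 1.3-fold lower number from compound 1 to compound 3 (0.12 log units; within the scatter), lie within the scatter, so no order among the three can be read from them.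

Compound 4 `CC(C)[C@@H](NC(=O)Nc1ccccc1)C(=O)N1CCC(c2ccc(Cl)cc2)CC1` is not yet measured. The change from compound 3: anilino in place of 1,3-benzothiazol-2-yl on a carbonyl carbon. For the measured compounds named here, the steps that bear on it are the earlier exchanges at the same carbonyl carbon: a 1.3-fold lower number from compound 1 to compound 2 (0.10 log units; within the scatter), a 1.3-fold lower number from compound 1 to compound 3 (0.12 log units; within the scatter) and a 1.1-fold lower number from compound 2 to compound 3 (0.02 log units; within the scatter), each within the scatter. Going by the values given here, no measured step tests an anilino group, so the expectation rests on the insensitivity seen so far. The step of a 1.4-fold higher number from compound 3 to compound 4 (0.14 log units; within the scatter) is expected to be none beyond the scatter. Compound 4 is estimated at 25 nM in this assay, with a range from 10 nM to 70 nM.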

Compound 4, half-maximal inhibitory concentration: 616 nM
The estimate for compound 4 lay 25-fold (1.39 log units) below the measured number, and the stated range ends below it.
By their numbers in this assay, from the lowest: compounds 3, 2 and 1 (each within the scatter of the next); then compound 4.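

The earlier exchanges at this carbonyl carbon had suggested a tolerant position, but in this assay the anilino group breaks that picture (a 34-fold higher number from compound 3 to compound 4 (1.53 log units; beyond the scatter)). The loss is of similar size against the other two groups (a 32-fold higher number from compound 2 to compound 4 (1.51 log units; beyond the scatter); a 26-fold higher number from compound 1 to compound 4 (1.41 log units; beyond the scatter)), so it does not depend on which of the three earlier groups serves as the reference. Tolerance at this position therefore extends to 1,3-benzothiazol-2-yl, 3-fluorophenyl and 2-(2-methylphenyl)ethyl but not to anilino, which, unlike 1,3-benzothiazol-2-yl, brings a hydrogen-bond donor and places a nitrogen directly on the carbonyl carbon.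

An N-methylanilino or a benzyl group on the same carbonyl carbon would show whether the loss follows that nitrogen and its hydrogen or the phenyl group it carries. Nothing among the data shown gives a reason for the loss.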